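This account rests on a few compounds, and the source may have more. Where it says the series, first, only, none or still open, it means among the compounds named here.

Values in a functional assay on OVCAR-3 cells (Homo sapiens) for antiproliferative activity, read by WST assay, with a stated time of 72 h; on this read-out higher numbers stand for weaker inhibition of growth and lower numbers for stronger inhibition of growth:
- Compound 1 `C#Cc1cccc(N/N=N/c2ccc(C(=N)N)cc2)c1`: 16800 nM
- Compound 2 `N=C(N)c1ccc(/N=N/Nc2cccc(C#Cc3ccccn3)c2)cc1`: 10700 nM
- Compound 3 `C#Cc1ccccc1N/N=N/c1ccc(C(=N)N)cc1`: > 25000 nM, a limit of the assay and not a number

Only compound 1 and compound 2 give true numbers, and these lie within the scatter of each other, so neither can be ranked above the other. Level with compound 1, compound 2 therefore stands at 10700 nM.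

Compound 4 `N=C(N)c1ccc(/N=N/Nc2cccc(C#Cc3ccccc3)c2)cc1` has not yet been measured. It carries phenyl in place of pyridin-2-yl on a triple-bonded carbon.

Within the data shown here, the one measured step at this place is a 1.6-fold lower number from compound 1 to compound 2 (0.20 log units; within the scatter). Among the measured compounds shown here, that step put pyridin-2-yl in place of hydrogen, and no measured pair exchanges one ring for the other, so the evidence for the new change is indirect. For the measured compounds named here, with that small step as the only guide, and with compound 2 at 10700 nM as the starting point, no change beyond the scatter is expected in this assay, in either direction.

The expected step is a 1.1-fold lower number from compound 2 to compound 4 (0.03 log units; within the scatter). The estimated value for compound 4 is 10000 nM, with an expected range from 4000 nM to 24000 nM.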

Compound 4, concentration for 50% growth inhibition: 6500 nM
For compound 4 the middle estimate is 1.5-fold (0.19 log units) above the measured one, and the stated range covers the measured number.
By their numbers in this assay, from the lowest: compounds 4, 2 and 1 (each within the scatter of the next, the first and the last beyond it). At a limit, above all of these: compound 3.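

In this assay, phenyl in place of pyridin-2-yl on the triple-bonded carbon gives a 1.6-fold lower number from compound 2 to compound 4 (0.22 log units; within the scatter), so losing the ring nitrogen and its hydrogen-bond acceptor brings no change that this read-out can resolve. Set against hydrogen at the same place, phenyl gives a 2.6-fold lower number from compound 1 to compound 4 (0.41 log units; beyond the scatter), the first step at this place to lie beyond the scatter, though it remains modest. Phenyl on the triple-bonded carbon thus gives stronger inhibition of growth than hydrogen, whereas compound 2, with pyridin-2-yl, stays within the scatter of both compound 1 and compound 4, so this cannot be claimed for every six-membered aromatic ring at this place.

The compounds shown leave open whether an amine or a carboxylic acid on the phenyl ring, or a longer chain on the triple-bonded carbon, would take the number further from that of compound 1. Compound 3 gives only a limit of the assay and not a number, so no step to it can be read: the limit of > 25000 nM in this assay, at which 1 of the 4 values shown sits.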